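The source may hold more compounds than are shown below. What is called first, only, known or untested is meant among the compounds shown, and "the series" means these compounds.

Compound 1 `CC(=O)NCC#CCn1cncc1C` and compound 3 `COC(=O)NCC#CCn1cncc1C` share one core, while compound 2 `CC(=O)N(C)CC#CCN1CCCC1` and compound 4 `COC(=O)N(C)CC#CCN1CCCC1` share another; the difference between the two cores is not broken down here. In a functional assay on the whole organism for agonist activity, with Mus musculus as the target (a lower number here means that less compound is needed, a higher number that more compound is needed for the effect), compound 1 gives only a limit, > 100 mg/kg. In this assay compound 3 likewise gives only a limit, > 100 mg/kg. The change from compound 1 to compound 3 is methoxy in place of methyl on a carbonyl carbon, and its step that the two limits leave unreadable from compound 1 to compound 3 cannot be read, since both values sit at the limit of > 100 mg/kg in this assay, at which 2 of the 3 values shown sit. In this assay, for the measured compounds named here, compound 2 gives 0.3 mg/kg, the only number among the three. Compound 4 carries the same change on the core of compound 2: methoxy in place of methyl on a carbonyl carbon. With the measured pair giving no readable size, the step from compound 2 to compound 4 is expected to be modest, a 3.3-fold higher number from compound 2 to compound 4 (0.52 log units; beyond the scatter), and compound 4 is estimated at 1 mg/kg.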

Compound 4, dose for half-maximal effect: 1.4 mg/kg
Estimate against measurement, compound 4: 1.4-fold (0.15 log units) below; measured number inside the range.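

In this assay, methoxy in place of methyl on a carbonyl carbon gives a 4.7-fold higher number from compound 2 to compound 4 (0.67 log units; beyond the scatter) on the core of compound 2, a size that lies beyond the scatter. On the core of compound 1 the same change cannot be read, because compound 1 and compound 3 each give only a limit and not a number: the limit of > 100 mg/kg in this assay, at which 2 of the 4 values shown sit. The compounds shown therefore offer only one readable step, and they do not show whether the change keeps its size from one core to the other. Open, from the compounds shown here alone, is how the core of compound 2 responds to other groups on the carbonyl carbon, such as ethoxy or an amine in place of methoxy.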